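This account rests on a few compounds, and the source may have more. Where it says the series, first, only, none or still open, it means among the compounds named here.

Two compounds of this series carry numbers in a functional assay on HEK293 cells for antagonist activity at P2X purinoceptor 7 (Rattus norvegicus), read by FLIPR and calcium flux; on this read-out lower numbers stand for stronger inhibition and higher numbers for weaker inhibition. Compound 1 `Cc1ccccc1N/C(=N\C#N)NC(NC(=O)CCCc1ccccc1)C(C)(C)C` gives 25.1 nM in this assay, the lowest of the two numbers; compound 2 `Cc1ncccc1N/C(=N\C#N)NC(NC(=O)CCCCc1ccccc1)C(C)(C)C` gives 50.1 nM, and the two numbers lie within the scatter of each other, so no order between them is claimed. Going by the values given here, compound 2 differs from compound 1 in more than one place, and no single step is drawn between them. Compound 3 `COc1ccc(CCCC(=O)NC(N/C(=N/C#N)Nc2ccccc2C)C(C)(C)C)cc1` is not yet measured. It differs from compound 1 in one place: methoxy in place of hydrogen on an aromatic carbon, the methoxy sitting para to a large group. Among the compounds with values here, no measured pair carries this change, so there is no step to lean on. The step from compound 1 to compound 3 in this assay is expected to be small, a 1.2-fold higher number from compound 1 to compound 3 (0.08 log units; within the scatter), with no direction claimed beyond the scatter. Compound 3 is therefore estimated at 30 nM, within 10 nM to 100 nM.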

Compound 3, half-maximal inhibitory concentration: 31.6 nM
Compound 3: middle estimate off by 1.1-fold (0.02 log units), on the low side; measured number inside the range.
By their numbers in this assay, from the lowest: compounds 1, 3 and 2 (each within the scatter of the next).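

In this assay, going by these compounds alone, the step of a 1.3-fold higher number from compound 1 to compound 3 (0.10 log units; within the scatter) is the first single-place change that can be read. At this aromatic carbon, para to a large group, the change from phenyl to 4-methoxyphenyl leaves the number within the scatter, so this position accepts methoxy without a measurable change in this read-out. No measurement shown gives a reason for this result.

On these data alone, whether an amine, a carboxylic acid or a trifluoromethyl group at the same carbon would also stay within the scatter remains open, as does the outcome of methoxy elsewhere on this ring. Compound 2 still differs from compound 1 in more than one place, so the separate contributions of those differences cannot be read.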